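The source may hold more compounds than are shown below. What is called first, only, known or untested is meant among the compounds shown, and "the series" means these compounds.

Compound 1 `Cn1c(=O)c(S(=O)(=O)c2ccc(OC(=O)CCCCC3SCC4NC(=O)NC43)cc2)cc2cnc(Nc3ccc4[nH]ccc4c3)nc21`: 400 nM
Compound 2 `Cn1c(=O)c(S(=O)(=O)c2ccc(F)cc2)cc2cnc(Nc3ccc4[nH]ccc4c3)nc21`: 200 nM

In a functional assay on SK-OV-3 cells (Homo sapiens) for inhibition, read by trypan blue exclusion, with a stated time of 72 h (a higher number here means a weaker inhibitor of growth, a lower number a stronger inhibitor of growth), compound 2 gives 200 nM, which lies within the scatter of compound 1 at 400 nM. Compound 3 `Cn1c(=O)c(S(=O)(=O)c2ccc(O)cc2)cc2cnc(Nc3ccc4[nH]ccc4c3)nc21` has hydroxy in place of fluoro on an aromatic carbon, para to a large group (hydroxy in place of fluoro on an aromatic carbon). Among the compounds with values here, no measured pair differs in one place alone, so this expectation has little direct support. The expected change is none beyond the scatter, with the estimated step of a 1.3-fold higher number from compound 2 to compound 3 (0.10 log units; within the scatter). For compound 3 the estimated value is 250 nM, with an expected range of 80 nM to 800 nM.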

Compound 3, concentration for 50% growth inhibition: 750 nM
Beside the measured number, compound 3's estimate is 3.0-fold (0.48 log units) below it; the measured number falls inside the stated range.
By their numbers in this assay, from the lowest: compounds 2, 1 and 3 (each within the scatter of the next, the first and the last beyond it).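

In this assay, within the data shown here, hydroxy in place of fluoro on an aromatic carbon, para to a large group, gives a 3.8-fold higher number from compound 2 to compound 3 (0.57 log units; beyond the scatter) in the first step here that differs in one place alone. The number for this position therefore responds to this exchange, although the step is modest and rests on a single pair. Nothing measured here accounts for the step. The compounds shown leave open how a methoxy group, an amine or a carboxylic acid at this position would compare with fluoro and hydroxy. They also leave open whether the step would recur with another group on the shared core.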